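A Methoxypyridinyl Variant Against a Row of Limits

The source may hold more compounds than are shown below. What is called first, only, known or untested is meant among the compounds shown, and "the series" means these compounds.

Compound 3 `CCCCNc1nc(N)nc2ccn(Cc3cccc(C)n3)c12` is one of three closely related compounds tested in an assay on HEK293 cells for agonist activity at Toll-like receptor 8 (Homo sapiens), read by a luciferase reporter, with a stated time of 6 h; on this read-out lower numbers stand for an effect already at smaller amounts and higher numbers for an effect only at larger amounts of compound. In this assay compound 3 gives > 25 uM, which is a limit of the assay and not a number. Compound 1 `CCCCNc1nc(N)nc2ccn(Cc3cccnc3)c12` gives > 25 uM in this assay, likewise a limit. Compound 2 `CCCCNc1nc(N)nc2ccn(Cc3ccncc3)c12` gives > 25 uM in this assay, again a limit. Because all three values sit at the limit of > 25 uM in this assay, at which 3 of the 3 values shown sit, the three steps among them, a step that the two limits leave unreadable from compound 1 to compound 2, a step that the two limits leave unreadable from compound 1 to compound 3 and a step that the two limits leave unreadable from compound 2 to compound 3, cannot be read in size or direction; they show only that none of the three exchanges on a saturated chain carbon bound to an aromatic nitrogen brought a compound below the limit.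

Compound 4 `CCCCNc1nc(N)nc2ccn(Cc3ncccc3OC)c12` has not yet been measured in this assay. It differs from compound 3 in one place: 3-methoxypyridin-2-yl in place of 6-methylpyridin-2-yl on a saturated chain carbon bound to an aromatic nitrogen. Among the compounds with values here, the only measured steps that bear on it are the three unreadable ones, so the data give neither a direction nor a size for the step; the expectation is that compound 4 stays near the limit as well. The step of a number no higher from compound 3 to compound 4 (the limit leaves the size open) is therefore estimated as none beyond the scatter. Compound 4 is expected to give about 25 uM in this assay, within a range from 8 uM to 60 uM, most likely reported once more only as a limit.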

Compound 4, minimum effective concentration: 0.59 uM
Compound 4: middle estimate off by 42-fold (1.63 log units), on the high side; the measured number lies below the stated range.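

The exchange on a saturated chain carbon bound to an aromatic nitrogen now has a readable outcome in this assay: 3-methoxypyridin-2-yl in place of 6-methylpyridin-2-yl gives an at least 42-fold lower number from compound 3 to compound 4 (1.62 log units; beyond the scatter) and in place of the other two rings gives an at least 42-fold lower number from compound 2 to compound 4 (1.62 log units; beyond the scatter) and an at least 42-fold lower number from compound 1 to compound 4 (1.62 log units; beyond the scatter) as well. Within the data shown here, the earlier compounds showed only that three pyridine-bearing groups at this place left the read-out at its limit, and the steps among them cannot be read, whereas compound 4 shows that a group at the same place can bring a measured number well under that limit. Compound 4 is the only one of the four with a number, and the three others remain limits of the assay: the limit of > 25 uM in this assay, at which 3 of the 4 values shown sit.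

All three new steps start from limits, so their true sizes stay open, and the compounds shown do not separate the methoxy group from the rest of the 3-methoxypyridin-2-yl group. Plain pyridin-2-yl, 3-methylpyridin-2-yl or 3-ethoxypyridin-2-yl at this place would be needed to tell how much of the step belongs to the methoxy group.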